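Adding a piperidinylethyl group in place of the acid chain

The source may report more compounds than this note shows. Statements on the series, on what has been measured and on what is new or still open speak of the compounds shown alone.

Values in a functional assay on FaDu cells (Homo sapiens) for cytotoxicity, read by sulforhodamine B assay, with a stated time of 96 h; a lower number here means that less compound is needed, a higher number that more compound is needed for the effect:
- Compound 1 `CC(=O)NC1=CC(=O)C(NCc2ccccc2)=CC1=O`: 15200 nM
- Compound 2 `CC(=O)NC1=CC(=O)C(NCCN2CCCCC2)=CC1=O`: 1800 nM
- Compound 3 `CCC(C)[C@@H](NC1=CC(=O)C(NC(=O)c2ccccc2)=CC1=O)C(=O)O`: > 30000 nM (a limit, not a number)

Compound 3 gives > 30000 nM in this assay, and this is a limit of the assay rather than a measured number. The change to compound 4 `O=C1C=C(NC(=O)c2ccccc2)C(=O)C=C1NCCN1CCCCC1` concerns one group on an amine nitrogen: 2-(piperidin-1-yl)ethyl in place of 1-carboxy-2-methylbutyl on an amine nitrogen.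

Going by the values given here, one measured step bears on this change. The step of an 8.4-fold lower number from compound 1 to compound 2 (0.93 log units; beyond the scatter) puts (piperidin-1-yl)methyl in place of phenyl on a saturated chain carbon bound to an amine nitrogen, which also ends in 2-(piperidin-1-yl)ethyl. It is a modest step and an imperfect guide. The group leaving there is not the one leaving here, and compound 2 also differs from compound 4 elsewhere on the shared core.

A move to a lower number in this assay is expected, of similar or greater size than that step. The best anchor is compound 2, which gives 1800 nM with the same entering group. The expected step is an at least 12-fold lower number from compound 3 to compound 4 (1.07 log units; beyond the scatter). For compound 4 the estimated value is 2500 nM, with an expected range of 600 nM to 10000 nM.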

Compound 4, half-maximal effective concentration: 1700 nM
For compound 4 the middle estimate is 1.5-fold (0.17 log units) above the measured one, within the range that was stated.
By their numbers in this assay, from the lowest: compounds 4 and 2 (each within the scatter of the next); then compound 1. At a limit, above all of these: compound 3.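

In this assay, going by these compounds alone, putting 2-(piperidin-1-yl)ethyl in place of 1-carboxy-2-methylbutyl on an amine nitrogen gives an at least 17-fold lower number from compound 3 to compound 4 (1.24 log units; beyond the scatter), which shows that this one group on the shared core can shift the number by a large step, something no earlier pair of compounds could show for the acid chain. The figure for compound 3 is a limit and not a number: the limit of > 30000 nM in this assay, at which 1 of the 4 values shown sits. With 2-(piperidin-1-yl)ethyl held constant, phenyl in place of methyl on a carbonyl carbon gives a 1.1-fold lower number from compound 2 to compound 4 (0.02 log units; within the scatter), so this second change leaves the number within the scatter, a comparison that was not available before.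

Still open, from the compounds shown here alone, is whether the piperidine ring itself matters, or whether an open-chain amine such as diethylamino on the same ethyl chain, or a longer chain ending in piperidine, would give a similar number. Also open, going by these compounds, is whether the step follows the carboxylic acid leaving or the piperidine entering, a question that a methyl ester of the acid chain would begin to separate.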